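Swapping the para-fluoro of compound 1 for a methoxy group

The source may report more compounds than this note shows. Statements on the series, on what has been measured and on what is new or still open speak of the compounds shown alone.

Compound 1, `O=C(Nc1ccc(Oc2ccnc3[nH]ccc23)cc1)c1cn(-c2ccc(F)cc2)c2ccccc2c1=O`, is the reference point of this small series. In a functional assay on A549 cells (Homo sapiens) for inhibition, read by MTT assay, with a stated time of 72 h (a lower number here means a stronger inhibitor, a higher number a weaker inhibitor), compound 1 gives 390 nM, the lowest of the three numbers recorded here. Compound 2, `O=C(Nc1ccc(Oc2ccnc3[nH]ccc23)cc1)c1cn(-c2ccc(Br)cc2)c2ccccc2c1=O`, gives 450 nM, and compound 3, `O=C(Nc1ccc(Oc2ccnc3[nH]ccc23)cc1)c1cn(-c2ccc(F)c(Cl)c2)c2ccccc2c1=O`, gives 4810 nM.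

Two steps from compound 1 are known. Replacing the fluoro with a bromo on the aromatic carbon brings a 1.2-fold higher number from compound 1 to compound 2 (0.06 log units; within the scatter), a change that sits inside the scatter. Adding a chloro in place of a hydrogen on the same ring brings a 12-fold higher number from compound 1 to compound 3 (1.09 log units; beyond the scatter), a large loss of potency; the same outcome is seen as an 11-fold higher number from compound 2 to compound 3 (1.03 log units; beyond the scatter).

Compound 4, `COc1ccc(-n2cc(C(=O)Nc3ccc(Oc4ccnc5[nH]ccc45)cc3)c(=O)c3ccccc32)cc1`, is not yet measured. It differs from compound 1 by methoxy in place of fluoro on an aromatic carbon. Among the measured compounds shown here, no measured step exchanges fluoro for methoxy, so only the tolerance seen for bromo in place of fluoro in the step from compound 1 to compound 2 bears on it, and the damage done by the extra chloro in compound 3 is a different kind of change. A small increase in the number, near the edge of the scatter, is expected, namely a 1.5-fold higher number from compound 1 to compound 4 (0.19 log units; within the scatter). Compound 4 is therefore estimated at 600 nM, with a likely range from 220 nM to 1700 nM.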

Compound 4, half-maximal inhibitory concentration: 4980 nM
Compound 4: the middle estimate sits 8.3-fold (0.92 log units) below what was measured; the measured number lies above the stated range.
By their numbers in this assay, from the lowest: compounds 1 and 2 (each within the scatter of the next); then compounds 3 and 4 (each within the scatter of the next).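

The position para to a large group proved less forgiving than the step from fluoro to bromo suggested. In this assay, methoxy in place of fluoro gives a large loss (shown by a 13-fold higher number from compound 1 to compound 4 (1.11 log units; beyond the scatter)), and methoxy in place of bromo gives a loss of similar size (shown by an 11-fold higher number from compound 2 to compound 4 (1.04 log units; beyond the scatter)), so the agreement between the two halogens at this position does not extend to every substituent. The exchange at this one position also leaves compound 4 level with compound 3 (shown by a 1.0-fold higher number from compound 3 to compound 4 (0.02 log units; within the scatter)), although compound 3 keeps the fluoro and carries an extra chloro, so two different changes to the 4-fluorophenyl ring end at indistinguishable numbers, and nothing given here offers a reason for the loss with methoxy.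

From the compounds shown here alone, whether the loss follows the oxygen of the methoxy, its carbon or the two together remains open, and a hydroxy or a methyl group at this position would begin to separate them. Whether the halogens are a special case also remains open, since the only substituents shown here are fluoro, bromo and methoxy, and an amine or a chloro alone at this position would test that.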